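The compounds below may be only part of what the source reports. "The series", "measured", "known", "first", "only" and "open" are said of these compounds alone.

Within the data shown here, in a functional assay on the whole organism with Mus musculus as the target (on this read-out lower numbers stand for an effect already at smaller amounts and higher numbers for an effect only at larger amounts of compound), compound 3 `Cn1nc(-c2ccccc2F)n(C)c1=S` gives 0.74 mg/kg, the only actual number among the three measured compounds. Compound 1 `Cn1nc(-c2ccc(Cl)cc2Cl)n(C)c1=S` reaches only a limit of the assay, > 25 mg/kg. Compound 2 `Cn1nc(-c2c(Cl)cccc2Cl)n(C)c1=S` also gives only a limit, > 50 mg/kg. Compound 4 `Cn1nc(-c2ccccc2Cl)n(C)c1=S` has yet to be tested in this assay, and its structure departs from that of compound 3 by one exchange: chloro in place of fluoro on an aromatic carbon. Among the measured compounds shown here, no measured pair isolates this exchange, so the expectation rests loosely on the two chloro-bearing compounds, which yielded no number. A moderate step toward larger doses, beyond the usual scatter, is expected, with the estimate being a 4.1-fold higher number from compound 3 to compound 4 (0.61 log units; beyond the scatter). For compound 4, the estimated value is 3 mg/kg, with an expected range from 0.8 mg/kg to 15 mg/kg.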

Compound 4, dose for half-maximal effect: 0.37 mg/kg
The estimate for compound 4 lay 8.1-fold (0.91 log units) above the measured number, and the stated range ends above it.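

Exchanging fluoro for chloro at this place on the ring leaves the read-out in this assay within the scatter, with a 2.0-fold lower number from compound 3 to compound 4 (0.30 log units; within the scatter). The large steps belong to the second chloro instead: an at least 130-fold lower number from compound 2 to compound 4 (2.13 log units; beyond the scatter), and an at least 67-fold lower number from compound 1 to compound 4 (1.82 log units; beyond the scatter), so a single chloro here does not go with the weak results of the dichloro compounds. Both of these steps start from a limit of the assay, not from a number.

On these data alone, what stays open is how a methoxy group or an amine at this place would read out, and how the ring would read out with hydrogen there.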